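Three Amides Show No Cytotoxicity; a Fourth Is Estimated

The source may report more compounds than this note shows. Statements on the series, on what has been measured and on what is new or still open speak of the compounds shown alone.

Compound 1 `O=C(Nc1cccc(Oc2nccc(C(F)(F)F)c2Cl)c1)C1CCCN(C(=O)c2cc(C(F)(F)F)cc(C(F)(F)F)c2)C1` was tested in an ADME assay on PC-3 cells (Homo sapiens) for cytotoxicity, read by WST assay, tested at 100 uM (on this read-out higher numbers stand for more inhibition at the one concentration tested (going by the name of the read-out) and lower numbers for less inhibition), and gave 0%. Two smaller amides sharing the same core were tested alongside it: compound 2 `C=Cc1cccc(C(=O)N2CCCC(C(=O)Nc3ccc(Cl)cc3)C2)c1`, which in this assay gave 0%, and compound 3 `CSc1cccc(C(=O)N2CCCC(C(=O)Nc3ccc(Cl)cc3)C2)c1`, which in this assay gave 0%. Among the compounds with values here, compound 1 therefore stands level with compound 2 and compound 3, and the one measured step between them, no change at the digits printed from compound 2 to compound 3 (within the scatter), shows that swapping one aromatic substituent for another did nothing to this read-out.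

Compound 4 `COC(=O)c1cc(-c2cccc(NC(=O)C3CCCN(C(=O)c4cc(C(F)(F)F)cc(C(F)(F)F)c4)C3)c2)co1` has not been measured in this assay. It differs from compound 1 in one place: 5-(methoxycarbonyl)furan-3-yl in place of (3-chloro-4-(trifluoromethyl)pyridin-2-yl)oxy on an aromatic carbon. Within the data shown here, no measured step follows this exact change, so the only guide is that every compound tested so far, whatever its substituent, sat at the bottom of the scale, and the step from compound 2 to compound 3 did not move it. Compound 4 is therefore expected to show no step beyond the scatter, no change at the digits printed from compound 1 to compound 4 (within the scatter), and its estimated value is 0%, with a range from 0% to 15%.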

Compound 4, a percentage reported as inhibition, at one concentration (the size of the read-out at that concentration, not a potency): 0%
For compound 4 middle estimate and measured number coincide at the digits printed; low and high end bracket the measured number.
By their numbers in this assay, from the lowest: compounds 1, 2, 3 and 4 (each within the scatter of the next).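

Replacing (3-chloro-4-(trifluoromethyl)pyridin-2-yl)oxy with 5-(methoxycarbonyl)furan-3-yl, on an aromatic carbon meta to a large group, gives no change at the digits printed from compound 1 to compound 4 (within the scatter) in this assay at this site. The earlier step exchanged only vinyl for methylsulfanyl in a smaller amide, whereas this one exchanges one ring-bearing group for a very different one: a six-membered aromatic ring with chlorine and trifluoromethyl gives way to a five-membered aromatic ring with methoxycarbonyl. Even so, the read-out stays at the bottom of its scale, and no measurement here offers an explanation for that.

With all four compounds at the bottom of the scale, the data cannot show whether any group at this position can raise the read-out. Going by these compounds, whether an amine, a carboxylic acid or a longer chain on this ring would do so remains open.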